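The compounds below may be only part of what the source reports. "The series", "measured", "known", "first", "only" and "open" are said of these compounds alone.

Compound 1 `CCCOc1ccc(C(=O)Nc2cccc(Cl)n2)cc1`: > 100000 nM
Compound 2 `CCCOc1ccc(C(=O)Nc2cccc(Nc3ccc(F)cc3)n2)cc1`: > 100000 nM

Compound 2 stands only at a limit in an in vitro assay on HEK-tsA201 cells for antagonist activity at Neuronal acetylcholine receptor; alpha4/beta2 (Homo sapiens), read by fluorescence and calcium flux (a lower number here means a stronger inhibitor, a higher number a weaker inhibitor), not at a number. Within the data shown here, the one measured step, a step that the two limits leave unreadable from compound 1 to compound 2, is therefore unreadable, since both values sit at the limit of > 100000 nM in this assay, at which 2 of the 2 values shown sit. Compound 3 `CCCOc1ccc(C(=O)Nc2cccc(Nc3ccc(Cl)cc3)n2)cc1` differs from compound 2 by chloro in place of fluoro on an aromatic carbon. Among the measured compounds shown here, no measured step bears on this change in this assay, and compound 2 gives only a limit, so no step beyond the scatter is expected in either direction; the estimated step that the limit leaves unreadable from compound 2 to compound 3 is accordingly flat. Compound 3 is expected at 150000 nM in this assay, with a range from 30000 nM to 1000000 nM.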

Compound 3, half-maximal inhibitory concentration: > 100000 nM
Compound 3 was reported as a limit; the forecaster's own chance of this, stated with the estimate: 85%; the middle value is on the limit's open side.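

Among these compounds, no step among compound 1, compound 2 and compound 3 can be read, as each is reported only as a limit: the limit of > 100000 nM in this assay, at which 3 of the 3 values shown sit.
In this assay the compounds shown leave open whether any change to the shared core gives a readable number.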